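Swapping methyl for methoxy on the carbonyl of compound 2

This account rests on a few compounds, and the source may have more. Where it says the series, first, only, none or still open, it means among the compounds named here.

Measured in a functional assay on the whole organism for antagonist activity, with Mus musculus as the target; a higher number here means that more compound is needed for the effect, a lower number that less compound is needed:
Compound 1 `CC(=O)N(C)C(C)C#CCn1ccnc1`: > 100 mg/kg (a limit, not a number)
Compound 2 `CC(=O)N(C)C(C)C#CCn1cncc1C`: 1.1 mg/kg
Compound 3 `CC(=O)N(C)CC#CCn1cncc1C`: 6.6 mg/kg

Compound 2 has the lower of the two actual numbers, so it needs the least compound of this set. Compound 4 `COC(=O)N(C)C(C)C#CCn1cncc1C` differs from it by methoxy in place of methyl on a carbonyl carbon. Neither measured step touches that carbon, so both offer only a rough guide to size. The first is large: an at least 90-fold lower number from compound 1 to compound 2 (1.95 log units; beyond the scatter). The second is modest: a 6.0-fold higher number from compound 2 to compound 3 (0.78 log units; beyond the scatter). A modest rise in this assay is therefore expected, in line with the step to compound 3. The estimated change is a 2.3-fold higher number from compound 2 to compound 4 (0.36 log units; beyond the scatter). For compound 4 the estimated value is 2.5 mg/kg, with an expected range of 0.6 mg/kg to 12 mg/kg.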

Compound 4, dose for half-maximal effect: 3.7 mg/kg
Compound 4: the middle estimate sits 1.5-fold (0.17 log units) below what was measured; low and high end bracket the measured number.
By their numbers in this assay, from the lowest: compound 2; then compounds 4 and 3 (each within the scatter of the next). At a limit, above all of these: compound 1.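

For the compounds shown here, the carbonyl carbon stays the same in the earlier compounds, so this is the first look at it: in this assay, going from acetyl to methoxycarbonyl gives a 3.4-fold higher number from compound 2 to compound 4 (0.53 log units; beyond the scatter). The position therefore accepts methoxy in place of methyl at a modest cost, and compound 4 still gives a real number rather than a limit.

Nothing measured here explains why this change raises the number. Going by these compounds, it also remains open how a longer chain such as ethoxy, or an amine such as dimethylamino, would fare on this carbonyl carbon.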